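The compounds below may be only part of what the source reports. "The series", "measured", "known", "first", "only" and "open" are said of these compounds alone.

Three esters that share the core of compound 1 `COc1cc(/C=C/C(=O)OC/C=C/CO[N+](=O)[O-])ccc1O` have been tested in a functional assay on NCI-H1299 cells (Homo sapiens) for cytotoxicity, read by resazurin assay, with a stated time of 72 h; on this read-out higher numbers stand for weaker inhibition and lower numbers for stronger inhibition. Compound 1 gives 2340 nM, compound 2 `COc1cc(/C=C/C(=O)OCCCCCO[N+](=O)[O-])ccc1O` gives 20800 nM, and compound 3 `COc1cc(/C=C/C(=O)OCCCO[N+](=O)[O-])ccc1O` gives 28300 nM. On these numbers compound 3 carries the highest value of the three, though its gap to compound 2, a 1.4-fold higher number from compound 2 to compound 3 (0.13 log units; within the scatter), is within the scatter, so the two cannot be ordered; the step of a 12-fold higher number from compound 1 to compound 3 (1.08 log units; beyond the scatter) is the only clear separation. Compound 4 `COc1cc(/C=C/C(=O)OC(C)C)ccc1O` has not yet been measured. The change is isopropyl in place of 3-(nitrooxy)propyl on an oxygen next to a carbonyl group. Both measured steps alter the same part of the molecule, the chain on the oxygen next to the carbonyl group, and together they show that this chain can shift the number a great deal in one case and hardly at all in another. Among the compounds with values here, neither step removes the nitrooxy group altogether, so no measured pair shows what an ester lacking it does. Given that compound 3 already sits at the high end, and that the isopropyl group keeps nothing of the departing chain, the number for compound 4 is expected to move higher rather than lower, with wide uncertainty. For compound 4 the expected step is therefore a 2.1-fold higher number from compound 3 to compound 4 (0.33 log units; beyond the scatter). Compound 4 is estimated at 60000 nM, with a range from 20000 nM to 200000 nM.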

Compound 4, half-maximal inhibitory concentration: > 50000 nM
Compound 4 ended at the assay's limit; the forecaster's own chance of this, stated with the estimate: 25%; the middle value lies beyond the limit too.
By their numbers in this assay, from the lowest: compound 1; then compounds 2 and 3 (each within the scatter of the next). At a limit, above all of these: compound 4.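

In this assay compound 4 sits at a limit of the assay, > 50000 nM, which is a limit and not a number. It is the first ester shown without a nitrooxy group, and the change at this oxygen, isopropyl in place of 3-(nitrooxy)propyl, gives an at least 1.7-fold higher number from compound 3 to compound 4 (0.24 log units; that floor lies within the scatter), so the result alone does not separate this pair beyond the scatter. What it adds is a first reading for this position with no nitrogen or oxygen in the entering group, and that reading is the only one of the series that reaches the top of the measurable range: the limit of > 50000 nM in this assay, at which 1 of the 4 values shown sits.

The compounds shown leave open how far past the limit compound 4 lies, and whether the nitrooxy group or the rest of the chain accounts for the step, as both leave together in this one change. A propyl chain ending in a hydroxyl group, or the chain of compound 1 ending in a hydroxyl group, would separate the two, and neither is among the compounds shown here.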